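The source may hold more compounds than are shown below. What is called first, only, known or untested is meant among the compounds shown, and "the series" means these compounds.

Of the compounds shown here, three sharing one core have been measured: compound 1 `Nc1cc(N)c2nc(-c3ccccc3)c(NCc3ccc(Cl)c(Cl)c3)nc2c1`, compound 2 `Nc1cc(N)c2nc(-c3ccccc3)c(Oc3ccc(F)cc3)nc2c1` and compound 3 `Nc1cc(N)c2nc(-c3ccccc3)c(Sc3ccc(Cl)c(Cl)c3)nc2c1`. In a functional assay on SF-295 cells (Homo sapiens) for inhibition, read by sulforhodamine B assay, with a stated time of 48 h (on this read-out lower numbers stand for stronger inhibition of growth and higher numbers for weaker inhibition of growth), compound 1 gives 37200 nM, compound 2 gives 38900 nM and compound 3 gives 60300 nM, the highest of the three numbers, though all three lie within the scatter of one another. The next compound, compound 4 `Nc1cc(N)c2nc(-c3ccccc3)c(NCc3ccc(F)cc3)nc2c1`, differs from compound 3 as follows: (4-fluorobenzyl)amino in place of (3,4-dichlorophenyl)sulfanyl on an aromatic carbon. Going by the values given here, the one directly comparable step, a 1.6-fold higher number from compound 2 to compound 3 (0.19 log units; within the scatter), changed little. Compound 1 carries a benzylamino group like compound 4 and its value sits within the scatter of compound 3, so no step beyond the scatter is expected for a 1.6-fold lower number from compound 3 to compound 4 (0.21 log units; within the scatter). Compound 4 is therefore estimated at 37000 nM, within 18000 nM to 76000 nM.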

Compound 4, concentration for total growth inhibition: 13500 nM
Beside the measured number, compound 4's estimate is 2.7-fold (0.44 log units) above it; the measured number lies below the stated range.
By their numbers in this assay, from the lowest: compound 4; then compounds 1, 2 and 3 (each within the scatter of the next).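

In this assay this position now shows steps beyond the scatter, both modest: a 4.5-fold lower number from compound 3 to compound 4 (0.65 log units; beyond the scatter) and a 2.9-fold lower number from compound 2 to compound 4 (0.46 log units; beyond the scatter), each with (4-fluorobenzyl)amino entering. The step of a 2.8-fold lower number from compound 1 to compound 4 (0.44 log units; beyond the scatter) keeps the benzylamino link and changes only the ring, with 4-fluorophenyl in place of 3,4-dichlorophenyl, so the ring's substituents matter here, not only the link to the core. Nothing available explains these steps. Still open, going by these compounds, is what a plain benzylamino group, with no halogen on the ring, or a longer chain between the nitrogen and the ring would give.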